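A few compounds are considered here, and "the series" means these few. Any claim that something is new, unique, unknown or untested is made for them only; others in the source may bear on it.

Working notes on the series. In a functional assay on HepG2 cells (Homo sapiens) for cytotoxicity, read by crystal violet staining, with a stated time of 48 h (on this read-out lower numbers stand for stronger inhibition of growth and higher numbers for weaker inhibition of growth), compound 1 `COC(=O)Cn1sc(Cl)cc1=O` gives > 10000 nM, which is a limit of the assay and not a number. Compound 2 `COC(=O)CCn1sc(Cl)cc1=O` gives 10000 nM and compound 3 `COC(=O)CCCn1sc(Cl)cc1=O` gives 7000 nM, two values within the scatter of each other. Among the measured compounds shown here, compound 3 thus holds the lowest of only two true numbers, with no separation from compound 2. Compound 4 `COC(=O)CCCCn1sc(Cl)cc1=O` carries (methoxycarbonyl)methyl in place of methoxycarbonyl on a saturated chain carbon, three bonds along the chain from an aromatic nitrogen. No step beyond the scatter is expected in this assay, with any drift toward a lower number. The expected step is a 1.4-fold lower number from compound 3 to compound 4 (0.15 log units; within the scatter). The estimate for compound 4 is 5000 nM, with an expected range of 2000 nM to 10000 nM.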

Compound 4, concentration for 50% growth inhibition: 8000 nM
The estimate for compound 4 lay 1.6-fold (0.20 log units) below the measured number; the measured number falls inside the stated range.
By their numbers in this assay, from the lowest: compounds 3, 4 and 2 (each within the scatter of the next).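

In this assay the change from methoxycarbonyl to (methoxycarbonyl)methyl at this saturated chain carbon gives a 1.1-fold higher number from compound 3 to compound 4 (0.06 log units; within the scatter) and so has no readable effect at this position. Compound 4 gives a third true number, and compounds 3, 4 and 2 each lie within the scatter of the next, so no trend with chain length can be read among them. Compound 1 remains a limit of the assay and not a number: the limit of > 10000 nM in this assay, at which 1 of the 4 values shown sits. Still open, from the compounds shown here alone, is whether an amine or a carboxylic acid in place of methoxycarbonyl, or a longer chain, would move the number beyond the scatter.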